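This account rests on a few compounds, and the source may have more. Where it says the series, first, only, none or still open, it means among the compounds named here.

Measured compounds:
compound 1, `C=C(C)C(=O)Nc1cc2c(N3CCc4ccccc43)ncnc2cc1OC`, 4830 nM
compound 2, `C=C(C)C(=O)Nc1cc2c(N3CCc4ccccc43)ncnc2cc1O[C@@H]1CCOC1`, 4910 nM
compound 3, `CCC/C=C/C(=O)Nc1cc2c(N3CCCc4ccccc43)ncnc2cc1O[C@@H]1CCOC1`, 11800 nM

In a functional assay on PC-3 cells (Homo sapiens) for antiproliferative activity, read by MTT assay, with a stated time of 72 h (a lower number here means a stronger inhibitor, a higher number a weaker inhibitor), compound 1 gives the lowest of the three numbers. Its nearest neighbour is compound 2, and the step of a 1.0-fold higher number from compound 1 to compound 2 (0.01 log units; within the scatter) lies within the scatter, so these two cannot be told apart. Compound 3 gives the furthest number, beyond the scatter from compound 1; it differs from compound 2 in two places at once, so its gap is not tied to one change.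

Compound 4, `COc1cc2ncnc(N3CCc4ccccc43)c2cc1NC(=O)/C=C/CN1CCC(CO)CC1`, has not been measured. It differs from compound 1 in a single place: 3-(4-(hydroxymethyl)piperidin-1-yl)prop-1-en-1-yl in place of 1-methylethenyl on a carbonyl carbon. Among the compounds with values here, none of the measured steps touches this part of the molecule; the only single-point step, a 1.0-fold higher number from compound 1 to compound 2 (0.01 log units; within the scatter), concerns the oxygen substituent and is flat, and compound 3 carries a different amide only together with a second change. The data therefore give no direct guide to the direction or size of the step. A moderate move toward a lower number is expected, with wide uncertainty, so that compound 4 is estimated at 2500 nM, within 800 nM to 8000 nM, which would mean a 1.9-fold lower number from compound 1 to compound 4 (0.29 log units; within the scatter).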

Compound 4, half-maximal inhibitory concentration: 2650 nM
Beside the measured number, compound 4's estimate is 1.1-fold (0.03 log units) below it; low and high end bracket the measured number.
By their numbers in this assay, from the lowest: compounds 4, 1 and 2 (each within the scatter of the next); then compound 3.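

Within the data shown here, compound 4 is the first case here in which the group on the carbonyl carbon changes on its own, whereas the earlier single-place step touched only the substituent on the oxygen. In this assay, replacing 1-methylethenyl with 3-(4-(hydroxymethyl)piperidin-1-yl)prop-1-en-1-yl gives a 1.8-fold lower number from compound 1 to compound 4 (0.26 log units; within the scatter) and so the two compounds cannot be told apart. This position therefore carries 11 heavy atoms in place of 3, including a six-membered non-aromatic ring and a hydrogen-bond donor, with no measurable cost in this cell read-out, although no measured property of these groups is available to explain the result.

The compounds shown do not separate the contributions of the hydroxymethyl, the piperidine ring and the chain that carries them, so it remains open how a morpholine, a plain piperidine or a carboxylic acid in place of the hydroxymethyl would read here. On these data alone, it is also open whether the same group on the carbonyl carbon would give a similar number when combined with the oxolan-3-yl on the oxygen.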